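This account rests on a few compounds, and the source may have more. Where it says the series, first, only, none or still open, it means among the compounds named here.

Compound 1 `COc1ccc(-c2ccc3c(NCCCNCc4cccc(OC)c4O)ccnc3c2)cc1`: 1600 nM
Compound 2 `COc1cccc(CNCCCNc2ccnc3cc(Oc4cccc(N(C)C)c4)ccc23)c1O`: 7300 nM
Compound 3 `c1ccc(-c2ccc3c(NCCCNCc4ccco4)ccnc3c2)cc1`: 5920 nM

All three were tested in an ADME assay on HepG2 cells (Homo sapiens) for cytotoxicity, read by luminescence, CellTiter-Glo and ATP content, with a stated time of 72 h; on this read-out higher numbers stand for an effect only at larger amounts of compound and lower numbers for an effect already at smaller amounts. Compound 3 gives 5920 nM, the second highest number of the three. Compound 2 lies within the scatter of compound 3, so the two cannot be told apart. Compound 1 shows a lower number, and that gap lies beyond the scatter, so compound 1 acts at smaller amounts than compound 3.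

Compound 4 `COc1cccc(CNCCCNc2ccnc3cc(-c4ccccc4)ccc23)c1O` is not yet measured. It differs from compound 3 in one place: 2-hydroxy-3-methoxyphenyl in place of furan-2-yl on a saturated chain carbon bound to an amine nitrogen. Among the measured compounds shown here, only one measured step is available, a 4.6-fold higher number from compound 1 to compound 2 (0.66 log units; beyond the scatter), and it changes a group on an aromatic carbon of the shared core, not the group on the chain carbon that changes here. It therefore does not bear directly on the present step. What the numbers do show is that compound 1 and compound 2, which both carry the entering 2-hydroxy-3-methoxybenzyl group, span the range from the lowest to the highest number in this assay, so that group on its own gives no clear direction.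

For compound 4 a small change is expected, a 1.7-fold lower number from compound 3 to compound 4 (0.23 log units; within the scatter), most likely within the scatter. The estimate for compound 4 is 3500 nM, with a range from 1200 nM to 10000 nM.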

Compound 4, half-maximal effective concentration: 3210 nM
Estimate against measurement, compound 4: 1.1-fold (0.04 log units) above; low and high end bracket the measured number.
By their numbers in this assay, from the lowest: compounds 1, 4, 3 and 2 (each within the scatter of the next, the first and the last beyond it).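

In this assay, going from the (furan-2-yl)methyl group to the 2-hydroxy-3-methoxybenzyl group gives a 1.8-fold lower number from compound 3 to compound 4 (0.27 log units; within the scatter) and so, despite the larger group with its added hydrogen-bond donor, this swap does not clearly shift the cell effect. With the 2-hydroxy-3-methoxybenzyl group held constant, the aromatic carbon of the shared core can now be compared in a second way: phenyl in place of 3-(dimethylamino)phenoxy gives a 2.3-fold lower number from compound 2 to compound 4 (0.36 log units; beyond the scatter) and is a modest shift that can be told apart from the scatter. A smaller edit at that same place, hydrogen in place of methoxy, gives a 2.0-fold higher number from compound 1 to compound 4 (0.30 log units; within the scatter) and thus goes against any idea that every change there counts, so only the exchange of the whole 3-(dimethylamino)phenoxy group stands out among these compounds.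

No measured data are available to explain why these steps have the sizes they do. Going by these compounds, it remains open whether a pyridine ring on the chain carbon, a longer chain, or a carboxylic acid on the phenyl ring would move the number beyond the scatter.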